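Shortening the hydroxycarbamoyl chain of compound 1

This account rests on a few compounds, and the source may have more. Where it says the series, first, only, none or still open, it means among the compounds named here.

Compound 1 `C=CC(=O)Nc1cc2c(Nc3ccc(OCc4cccc(F)c4)c(Cl)c3)ncnc2cc1OCc1cn(CCCCC(=O)NO)nn1` is the starting point for this step. In a functional assay on SK-BR-3 cells (Homo sapiens) for antiproliferative activity, read by MTT assay, with a stated time of 72 h (on this read-out lower numbers stand for stronger inhibition and higher numbers for weaker inhibition), compound 1 gives 16000 nM. Compound 3 `C=CC(=O)Nc1cc2c(Nc3ccc(F)c(Cl)c3)ncnc2cc1OCc1cn(CCCC(=O)NO)nn1` gives 30800 nM, which lies within the scatter of the number for compound 1. Compound 2 `C=CC(=O)Nc1cc2c(Nc3cccc(Cl)c3F)ncnc2cc1OCc1cn(CCCCC(=O)NO)nn1` returns no number, only a limit of > 50000 nM.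

The next compound to be tested is compound 4 `C=CC(=O)Nc1cc2c(Nc3ccc(OCc4cccc(F)c4)c(Cl)c3)ncnc2cc1OCc1cn(CCC(=O)NO)nn1`, which keeps the rest of compound 1 and changes only the chain. Hydroxycarbamoyl stands in place of 2-(hydroxycarbamoyl)ethyl on a saturated chain carbon, two bonds along the chain from an aromatic nitrogen (hydroxycarbamoyl in place of 2-(hydroxycarbamoyl)ethyl on a saturated chain carbon, two bonds along the chain from an aromatic nitrogen). Cut one bond further out, the same difference reads 4-(hydroxycarbamoyl)butyl to 2-(hydroxycarbamoyl)ethyl.

Going by the values given here, no two measured compounds differ in one place only, so the series gives no direct measure of what this change does. A small step towards weaker inhibition is expected in this assay, close to the edge of the scatter, with compound 3 at 30800 nM as the nearest measured number. The expected change is a 1.5-fold higher number from compound 1 to compound 4 (0.18 log units; within the scatter). For compound 4 the estimated value is 24000 nM, with an expected range of 9000 nM to 50000 nM.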

Compound 4, half-maximal inhibitory concentration: 24800 nM
Compound 4: middle estimate off by 1.0-fold (0.01 log units), on the low side; low and high end bracket the measured number.
By their numbers in this assay, from the lowest: compounds 1, 4 and 3 (each within the scatter of the next). At a limit, above all of these: compound 2.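

Going by these compounds alone, this is the first comparison between compounds that differ in one place only: with the rest of the molecule kept, going from 4-(hydroxycarbamoyl)butyl to 2-(hydroxycarbamoyl)ethyl gives a 1.6-fold higher number from compound 1 to compound 4 (0.19 log units; within the scatter) in this assay. Over these two chain lengths the read-out does not tell the pair apart, so at this position on the chain the shorter group brings no change that can be read. Compound 2, which does not belong to this pair, alone stands at a limit, which is not a number, while the pair itself stays within the measurable range: the limit of > 50000 nM in this assay, at which 1 of the 4 values shown sits.

Going by these compounds, it remains open whether a chain longer than 4-(hydroxycarbamoyl)butyl, or a carboxylic acid in place of the hydroxycarbamoyl end, would move the number beyond the scatter. Also open is whether the same chain change reads the same way with a different group elsewhere on the molecule, since only one pair shown here carries it.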